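A Spiro Core Series: Changing the Amide Side Chain

The compounds below may be only part of what the source reports. "The series", "measured", "known", "first", "only" and "open" are said of these compounds alone.

Measured in an assay on HEK293 cells for displacement of a labelled ligand from NPC1-like intracellular cholesterol transporter 1 (Homo sapiens); a higher number here means a weaker inhibitor, a lower number a stronger inhibitor:
compound 1 `CC(C)(C)c1ccc(C(=O)N2CCC3(CC2)C(=O)N(CC(=O)NCCN)CN3c2ccccc2)cc1` gives 7000 nM
compound 2 `CC(C)(C)c1ccc(C(=O)N2CCC3(CC2)C(=O)N(CC(=O)NCCC(=O)O)CN3c2ccccc2)cc1` gives 11400 nM
compound 3 `CC(C)(C)c1ccc(C(=O)N2CCC3(CC2)C(=O)N(CC(=O)NCN)CN3c2ccccc2)cc1` gives 26500 nM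

Compound 3 stands highest of the three numbers; the steps onto it were a 2.3-fold higher number from compound 2 to compound 3 (0.37 log units; beyond the scatter) and a 3.8-fold higher number from compound 1 to compound 3 (0.58 log units; beyond the scatter).

Compound 4 `CC(C)(C)c1ccc(C(=O)N2CCC3(CC2)C(=O)N(CC(=O)N2CCCCC2CO)CN3c2ccccc2)cc1` is not yet measured. It differs from compound 3 by 2-(hydroxymethyl)piperidin-1-yl in place of (aminomethyl)amino on a carbonyl carbon. The two measured steps ending at compound 3 bear on this change: a 3.8-fold higher number from compound 1 to compound 3 (0.58 log units; beyond the scatter) and a 2.3-fold higher number from compound 2 to compound 3 (0.37 log units; beyond the scatter), each a modest rise when amino replaced aminomethyl on the chain carbon bound to the amide-type nitrogen. Compound 4 instead carries a larger group on the carbonyl carbon, so a modest fall, beyond the scatter, is expected, toward the range of compound 1 and compound 2. Compound 4 is therefore estimated at 8000 nM, with a range of 3000 nM to 25000 nM, meaning an expected 3.3-fold lower number from compound 3 to compound 4 (0.52 log units; beyond the scatter).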

Compound 4, half-maximal inhibitory concentration: 11800 nM
The estimate for compound 4 lay 1.5-fold (0.17 log units) below the measured number, and the stated range covers the measured number.
By their numbers in this assay, from the lowest: compounds 1, 2 and 4 (each within the scatter of the next); then compound 3.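

In this assay, 2-(hydroxymethyl)piperidin-1-yl on the carbonyl carbon in place of (aminomethyl)amino gave a 2.2-fold lower number from compound 3 to compound 4 (0.35 log units; beyond the scatter), while the comparisons with the two longer side chains gave a 1.0-fold higher number from compound 2 to compound 4 (0.01 log units; within the scatter) and a 1.7-fold higher number from compound 1 to compound 4 (0.23 log units; within the scatter). A six-membered non-aromatic ring at this position therefore leaves compound 4 within the scatter of compound 1 and compound 2, and only compound 3 stands apart from the other three. No measurement shown here accounts for this result.

As far as these compounds go, it remains open whether a plain piperidin-1-yl without the hydroxymethyl would give a similar number. The same applies to a longer chain ending in an amine or a carboxylic acid.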